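Moving Aryl Chlorines on a Melanoma Cytotoxicity Series

The compounds below may be only part of what the source reports. "The series", "measured", "known", "first", "only" and "open" are said of these compounds alone.

Measured compounds:
compound 1 `O=C1/C(=C\c2ccccc2Cl)c2ccccc2N1c1c(Cl)cccc1Cl` – 39 ug/mL
compound 2 `O=C1/C(=C\c2ccc(Cl)cc2)c2ccccc2N1c1c(Cl)cccc1Cl` – > 100 ug/mL

Both compounds were tested in a functional assay on B16-F10 cells (Homo sapiens) for cytotoxicity against B16-F10 (Mus musculus), read by MTT assay, with a stated time of 72 h; on this read-out lower numbers stand for an effect already at smaller amounts and higher numbers for an effect only at larger amounts of compound. Compound 1 gives 39 ug/mL. Compound 2 gives > 100 ug/mL, which is a limit of the assay and not a number, as noted in the limit of > 100 ug/mL in this assay, at which 1 of the 2 values shown sits. Going by the values given here, the one measured step is an at least 2.5-fold higher number from compound 1 to compound 2 (0.40 log units; beyond the scatter). So compound 2 stands at the weak end of what has been seen, and its true value is known only as a limit.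

Compound 3 `O=C1/C(=C\c2c(Cl)cccc2Cl)c2ccccc2N1c1c(Cl)cccc1Cl` is not yet measured. It differs from compound 2 in one place: 2,6-dichlorophenyl in place of 4-chlorophenyl on a double-bonded chain carbon bound to a double-bonded ring carbon. Among the compounds with values here, the only measured step that bears on this is an at least 2.5-fold higher number from compound 1 to compound 2 (0.40 log units; beyond the scatter), in which 2-chlorophenyl gave way to 4-chlorophenyl and the number rose beyond the scatter. The change to compound 3 runs the other way, bringing back the 2-chlorophenyl pattern and adding a second chlorine. A step back down toward the number of compound 1 is therefore expected in this assay, though with room for a limit again. Compound 3 is expected to give 45 ug/mL, between 15 ug/mL and 100 ug/mL. That expectation amounts to an estimated step of an at least 2.2-fold lower number from compound 2 to compound 3 (0.34 log units; beyond the scatter).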

Compound 3, concentration for half-maximal effect: > 100 ug/mL
Compound 3: only a limit was reported; the forecaster's own chance of this, stated with the estimate: 35%; middle value at least 2.2-fold (0.34 log units) from the limit.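

In this assay compound 3 gives > 100 ug/mL, which is a limit and not a number. Adding chloro in place of hydrogen on an aromatic carbon of the 2-chlorophenyl group gives an at least 2.5-fold higher number from compound 1 to compound 3 (0.40 log units; beyond the scatter), so the 2-chlorophenyl pattern does not keep its measurable effect once a second chlorine joins it, and among the three compounds shown only the group with a single chlorine in that pattern yields a number at all. The step between the 4-chlorophenyl and 2,6-dichlorophenyl compounds cannot be read, and the reason is that both sit at the same limit: the limit of > 100 ug/mL in this assay, at which 2 of the 3 values shown sit.

From the compounds shown here alone, how far compound 2 and compound 3 lie beyond that limit stays unknown, so it remains open which of the two is weaker. Going by these compounds, it also remains open whether the loss in going to 2,6-dichlorophenyl is tied to chlorine itself or would also appear with a different second group on that ring, such as a methoxy group or an amine.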